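The source may hold more compounds than are shown below. What is called first, only, known or untested is meant among the compounds shown, and "the series" means these compounds.

Working notes on the series. Two members have been run in a functional assay on HOS-TE85 cells (Homo sapiens) for inhibition, read by CCK-8 assay, with a stated time of 72 h, tested at 1 uM; a higher number here means more inhibition at the concentration tested (going by the name of the read-out), a lower number less inhibition. Compound 1 `COc1ccccc1N1C(=O)C(C)SC1c1cccc(C(=O)NCCCCc2ccccc2)c1` gives 95% in this assay. Compound 2 `COc1ccc(OC)c(N2C(=O)CSC2c2cccc(C(=O)NCCCCc3ccccc3)c2)c1` gives 20% in this assay, the lowest of the two numbers; its nearest neighbour is compound 1, a number that stands beyond the scatter above it. Among the compounds with values here, compound 1 and compound 2 differ in more than one place, so no single step between them is given; only the two values themselves are known.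

Compound 3 `O=C(NCCCCc1ccccc1)c1cccc(C2SCC(=O)N2c2cccc(F)c2)c1` remains to be measured in this assay. It differs from compound 2 in one place: 3-fluorophenyl in place of 2,5-dimethoxyphenyl on an amide-type nitrogen in a ring. Within the data shown here, only compound 2 gives a direct anchor for this change, and no comparable step has been measured. A rise is expected, with wide uncertainty, as the step of a number 30 percentage points higher from compound 2 to compound 3 (beyond the scatter). The estimate for compound 3 in this assay is 50%, expected to fall between 15% and 90%.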

Compound 3, a percentage reported as inhibition, at one concentration (the size of the read-out at that concentration, not a potency): 94%
Compound 3: the middle estimate sits 44 percentage points below what was measured, and the stated range ends below it.
By their numbers in this assay, from the lowest: compound 2; then compounds 3 and 1 (each within the scatter of the next).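

In this assay the group on the amide-type nitrogen in a ring now has a single-place step of its own: 3-fluorophenyl in place of 2,5-dimethoxyphenyl gives a number 74 percentage points higher from compound 2 to compound 3 (beyond the scatter) with the rest of the structure unchanged. This shows that a change at this one position is enough to move a member of the series from the low end to the high end of the numbers seen so far. No measurement on hand accounts for the size of this step.

The change removes both methoxy groups and adds fluorine in one move, so the compounds shown do not separate the two. Also open, from the compounds shown here alone, is how plain phenyl, 3-methoxyphenyl or 3-chlorophenyl at this position would read out.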